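Tetrazole Exchanged for Carboxymethyl: Expectation for Compound 4

A few compounds are considered here, and "the series" means these few. Any claim that something is new, unique, unknown or untested is made for them only; others in the source may bear on it.

Compound 2 `CC(C)(C)CC[C@H](c1ccc(C(=O)NCCC2=NNNN2)cc1)N1C(=O)C(c2cc(Cl)cc(Cl)c2)=N[C@]12CC[C@@H](C(C)(C)C)CC2` gives 890 nM in a functional assay on CHO cells for antagonist activity at Glucagon receptor (Homo sapiens), read by cAMP accumulation, with stated times of 30 min and 45 min (on this read-out lower numbers stand for stronger inhibition and higher numbers for weaker inhibition), the highest of the three numbers shown, though the others lie within the usual scatter: compound 3 `CC(C)(C)[C@H]1CC[C@]2(CC1)N=C(c1cccc(Cl)c1)C(=O)N2Cc1ccc(C(=O)NCCC(=O)O)cc1` gives 770 nM and compound 1 `C[C@H](c1ccc(C(=O)NCCC(=O)O)cc1)N1C(=O)C(c2cccc(Cl)c2)=N[C@]12CC[C@@H](C(C)(C)C)CC2` gives 480 nM. Among the compounds with values here, the only single-point step among the measured compounds is a 1.6-fold higher number from compound 1 to compound 3 (0.21 log units; within the scatter). Compound 4 `CC(C)(C)CC[C@H](c1ccc(C(=O)NCCCC(=O)O)cc1)N1C(=O)C(c2cc(Cl)cc(Cl)c2)=N[C@]12CC[C@@H](C(C)(C)C)CC2` differs from compound 2 on a saturated chain carbon, two bonds along the chain from an amide-type nitrogen: a group of 4 heavy atoms (2 carbon, 2 oxygen; no ring) in place of a group of 5 heavy atoms (1 carbon, 4 nitrogen; one five-membered non-aromatic ring with 4 hetero atoms), on a saturated chain carbon, two bonds along the chain from an amide-type nitrogen. Within the data shown here, no measured pair shows this exchange, and the one known step in this assay barely moves the number. The step from compound 2 to compound 4 is therefore expected to be a 1.0-fold higher number from compound 2 to compound 4 (0.00 log units; within the scatter), nothing beyond the scatter. Compound 4 is estimated at 900 nM, between 400 nM and 2000 nM.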

Compound 4, half-maximal inhibitory concentration: 350 nM
Beside the measured number, compound 4's estimate is 2.6-fold (0.41 log units) above it, and the stated range ends above it.
By their numbers in this assay, from the lowest: compounds 4, 1, 3 and 2 (each within the scatter of the next, the first and the last beyond it).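

At this saturated chain carbon, two bonds along the chain from an amide-type nitrogen, carboxymethyl in place of the five-membered ring with 4 hetero atoms gives a 2.5-fold lower number from compound 2 to compound 4 (0.41 log units; beyond the scatter) in this assay. Within the data shown here, the number therefore depends on the group held at this position, something the one earlier step, a change at another place and within the scatter, could not show. Nothing measured here gives a reason for this shift. As far as these compounds go, it remains open how an amine or a longer chain ending in a carboxylic acid would fare at this carbon. From the compounds shown here alone, it also remains open whether the same exchange would give a similar step with other groups around the shared core.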